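From a pyridyl amide to a phenyl sulfonamide

A few compounds are considered here, and "the series" means these few. Any claim that something is new, unique, unknown or untested is made for them only; others in the source may bear on it.

Among the measured compounds shown here, compound 2 `CN(C(=O)c1cccnc1)c1ccc(C(O)(C(F)(F)F)C(F)(F)F)cc1` is the only compound here with a plain number in an ADME assay on Li23 cells (Homo sapiens) for cytotoxicity, read by WST assay; a lower number here means that less compound is tolerated, a higher number that more compound is tolerated: compound 2 gives 63000 nM. Compound 1 `CN(C(=O)c1ccccn1)c1ccc(C(O)(C(F)(F)F)C(F)(F)F)cc1` differs from it only in the ring on the carbonyl carbon, and in this assay compound 1 reaches only a limit, > 100000 nM. For the measured compounds named here, the one measured step, an at least 1.5-fold lower number from compound 1 to compound 2 (0.20 log units; that floor lies within the scatter), is therefore only a floor, and one of the two values is a limit (the limit of > 100000 nM in this assay, at which 1 of the 2 values shown sits). Compound 3 `CN(c1ccc(C(O)(C(F)(F)F)C(F)(F)F)cc1)S(=O)(=O)c1ccccc1` departs from compound 2 in a different way: phenylsulfonyl in place of (pyridin-3-yl)carbonyl on a nitrogen on an aromatic ring. No measured step matches the exchange of a carbonyl link for a sulfonyl link, so the single step shown, which concerns the ring rather than the link, gives little guidance beyond placing both measured compounds at high concentrations. The expectation is thus a step within the scatter, a 1.3-fold lower number from compound 2 to compound 3 (0.10 log units; within the scatter). Compound 3 is expected to give about 50000 nM, between 15000 nM and 100000 nM.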

Compound 3, half-maximal cytotoxic concentration: 16000 nM
Compound 3: the middle estimate sits 3.1-fold (0.49 log units) above what was measured; the range from low to high includes it.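

Among the compounds shown here, at this nitrogen, phenylsulfonyl in place of (pyridin-3-yl)carbonyl gives a 3.9-fold lower number from compound 2 to compound 3 (0.60 log units; beyond the scatter) in this assay, the first step here between two plain numbers and one that lies beyond the scatter. The same group in place of (pyridin-2-yl)carbonyl gives an at least 6.2-fold lower number from compound 1 to compound 3 (0.79 log units; beyond the scatter) as a floor only, not a full size: the limit of > 100000 nM in this assay, at which 1 of the 3 values shown sits. So the group on this nitrogen can shift the tolerated concentration beyond the scatter, yet the link and the ring change together here, and neither can be credited alone.

As far as these compounds go, what remains open is how much the link and the ring each count, which a phenylcarbonyl group or a (pyridin-3-yl)sulfonyl group on this nitrogen would separate. Also open, from the compounds shown here alone, is whether an amine or a carboxylic acid on the ring of the phenylsulfonyl group would move the number in this assay at all.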